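The compounds below may be only part of what the source reports. "The series", "measured", "known", "first", "only" and "open" are said of these compounds alone.

Measured compounds:
compound 1 `CCN1CCC(NC(=O)c2cccc3[nH]cnc23)CC1` — in an assay on membranes from striatum for binding affinity to 5-hydroxytryptamine receptor 4 (Rattus norvegicus) (on this read-out higher numbers stand for weaker inhibition and lower numbers for stronger inhibition), compound 1 gives > 1000 nM, which is a limit of the assay and not a number.
compound 2 `CS(=O)(=O)NCCN1CCC(CNC(=O)c2cccc3[nH]cnc23)CC1` — in this assay compound 2 gives 11.4 nM.

Going by the values given here, compound 2 stands alone as the only number measured in this assay; the other value shown for the series is a limit, and compound 1 sits at it (the limit of > 1000 nM in this assay, at which 1 of the 2 values shown sits). Among the compounds with values here, no two measured compounds differ in a single place, so no measured step is available, and what compound 1 and compound 2 show together is only that one gives a limit and the other a number.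

Compound 3 `CS(=O)(=O)NCCN1CCC(CNC(=O)c2cc(Cl)cc3[nH]cnc23)CC1` has not yet been measured. It differs from compound 2 by chloro in place of hydrogen on an aromatic carbon. Within the data shown here, with no measured step to lean on, the working expectation is a small change at most. The step of a 1.4-fold lower number from compound 2 to compound 3 (0.15 log units; within the scatter) is expected to stay within the usual scatter. For compound 3 in this assay the estimate is 8 nM, with a range from 3 nM to 25 nM.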

Compound 3, inhibition constant: 0.11 nM
The estimate for compound 3 lay 73-fold (1.86 log units) above the measured number, and the stated range ends above it.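

In this assay, going by these compounds alone, the position on the aromatic carbon that is meta to a fused ring, meta to a large group and para to a fused ring proves highly sensitive to substitution: chloro in place of hydrogen gives a 100-fold lower number from compound 2 to compound 3 (2.02 log units; beyond the scatter) in the only single-place comparison. The earlier compounds shown here gave no reading of this position, whereas this step shows that one added heavy atom, with 0 hydrogen-bond donors, 0 hydrogen-bond acceptors and no net charge, can shift the number well beyond the scatter. Nothing measured in the series accounts for the size of this step.

The compounds shown leave open whether the step is particular to chloro or would also appear with fluoro, methyl, methoxy or an amine at this position. As far as these compounds go, compound 1 gives > 1000 nM, a limit of the assay and not a number, so it also stays open whether chloro at this position would bring a measurable value on the core of compound 1.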